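The source may report more compounds than this note shows. Statements on the series, on what has been measured and on what is new or still open speak of the compounds shown alone.

In an ADME assay on TZM cells (Homo sapiens) for cytotoxicity (on this read-out higher numbers stand for lower toxicity in this test and lower numbers for higher toxicity in this test), compound 1 `COC(=O)c1cc(N)c(Nc2ccc(C#N)cc2)cc1Oc1c(C)cc(/C=C/C#N)cc1C` gives > 22800 nM, which is a limit. Compound 2 `Cc1cc(/C=C/C#N)cc(C)c1Oc1cc(Nc2ccc(C#N)cc2)c(N)cc1C(=O)O` gives a true number, 14900 nM. Compound 3 `CNC(=O)c1cc(N)c(Nc2ccc(C#N)cc2)cc1Oc1c(C)cc(/C=C/C#N)cc1C` stands at > 9200 nM, which is also a limit, so its place on the scale is not fixed by a number.

The next compound, compound 4 `Cc1cc(/C=C/C#N)cc(C)c1Oc1cc(Nc2ccc(C#N)cc2)c(N)cc1CO`, carries hydroxymethyl in place of methylcarbamoyl on an aromatic carbon. Going by the values given here, no measured step makes this exact change, but three steps alter the group at the same place on the shared core. The first is an at least 1.5-fold lower number from compound 1 to compound 2 (0.18 log units; that floor lies within the scatter). The other two are a step that the two limits leave unreadable from compound 1 to compound 3 and a step that the limit leaves unreadable from compound 2 to compound 3. None of these shows a change beyond the scatter, so no clear shift in either direction is expected in this assay. Among the compounds with values here, the estimate therefore leans on compound 2 at 14900 nM, the only true number in the set. The expected step is a step that the limit leaves unreadable from compound 3 to compound 4. For compound 4 the estimated value is 16000 nM, with an expected range from 6000 nM to 40000 nM.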

Compound 4, half-maximal cytotoxic concentration in the TZM assay: 16300 nM
Beside the measured number, compound 4's estimate is 1.0-fold (0.01 log units) below it, within the range that was stated.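

In the TZM assay, compound 4 adds a second true number at this position, and hydroxymethyl can now be set against two other groups there. The change from carboxy gives a 1.1-fold higher number from compound 2 to compound 4 (0.04 log units; within the scatter), and the change from methoxycarbonyl gives an at least 1.3-fold lower number from compound 1 to compound 4 (0.14 log units; that floor lies within the scatter). The same position does show a shift beyond the scatter in a physicochemical assay for solubility, read by HPLC, at pH 2 (on this read-out higher numbers stand for higher solubility and lower numbers for lower solubility), where hydroxymethyl in place of methylcarbamoyl goes with a higher number: the measured solubility of compound 3, 8.63 ug/mL, and of compound 4, 21 ug/mL, a 2.4-fold higher number (0.39 log units; beyond the scatter). In the physicochemical assay compound 3 gives 8.63 ug/mL and compound 4 gives 21 ug/mL.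

In the TZM assay compound 3 gives > 9200 nM, which is a limit, so the step from compound 3 to compound 4 in that assay cannot be read. On these data alone, whether a longer chain such as hydroxyethyl, or an amine such as aminomethyl, would behave like hydroxymethyl at this position in either assay stays open.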